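From methoxy to 4-chlorobutoxy on compound 1

The source may hold more compounds than are shown below. What is called first, only, known or untested is meant among the compounds shown, and "the series" means these compounds.

- compound 1 `CCCCCC[C@@]1(C)SC(=O)C=C1OC` gives 9.4 ug/mL
- compound 2 `CCCCCCCC[C@@]1(C)SC(=O)C=C1OC` gives 16.4 ug/mL
- compound 3 `CCCCCC[C@@]1(C)SC(=O)C=C1OCCCCCl` has not yet been measured

Within the data shown here, in a functional assay on MCF7 cells (Homo sapiens) for inhibition, read by radiometric assay and XTT assay (on this read-out lower numbers stand for stronger inhibition and higher numbers for weaker inhibition), compound 1 gives 9.4 ug/mL and sits level with compound 2, the only other measured compound. Among the measured compounds shown here, the one measured step is a 1.7-fold higher number from compound 1 to compound 2 (0.24 log units; within the scatter) and puts ethyl in place of hydrogen on a saturated chain carbon, so the two numbers cannot be told apart.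

Compound 3 keeps the core of compound 1 but differs elsewhere: 3-chloropropyl in place of hydrogen on a saturated chain carbon bound to an oxygen on an unsaturated carbon. Read one bond further out, this turns methoxy into 4-chlorobutoxy. For the measured compounds named here, no measured step tests a change at this place, so the evidence is thin. Going by the values given here, the only hint comes from compound 2, where adding to a different chain gave a 1.7-fold higher number from compound 1 to compound 2 (0.24 log units; within the scatter) and nothing beyond the scatter. A clear change in this assay is therefore not expected, and any lean towards a higher number is only slight. The expected step is a 1.3-fold higher number from compound 1 to compound 3 (0.11 log units; within the scatter) and remains uncertain. For compound 3 the estimated value is 12 ug/mL, with an expected range from 4.5 ug/mL to 32 ug/mL.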

Compound 3, half-maximal inhibitory concentration: 20.8 ug/mL
Compound 3: the middle estimate sits 1.7-fold (0.24 log units) below what was measured; the range from low to high includes it.
By their numbers in this assay, from the lowest: compounds 1, 2 and 3 (each within the scatter of the next, the first and the last beyond it).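

This position, a saturated chain carbon bound to an oxygen on an unsaturated carbon, had not been tested before, and turning methoxy into 4-chlorobutoxy gives in this assay a 2.2-fold higher number from compound 1 to compound 3 (0.34 log units; beyond the scatter). Among these compounds, that step is modest, but it clears the scatter, which the only earlier step, at a different chain, did not: a 1.7-fold higher number from compound 1 to compound 2 (0.24 log units; within the scatter). So in this one pair, the methoxy group cannot be swapped for 3-chloropropyl-extended 4-chlorobutoxy without a readable weakening of inhibition, and no measurement at hand offers an explanation for this shift.

The compounds shown leave open whether the step belongs to the added carbons or to the chlorine, and a plain butoxy group, which carries no chlorine, would separate the two. Also open, as far as these compounds go, is how an amine or a carboxylic acid in place of that chlorine would read in this assay, and whether a longer chain on the oxygen would push the number further in the same direction or leave it where it is.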